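Acetamido for cyclopropylcarbonylamino on a thiazole-type amine

The source may hold more compounds than are shown below. What is called first, only, known or untested is meant among the compounds shown, and "the series" means these compounds.

Measured so far:
compound 1 `COc1c(NS(=O)(=O)c2ccc(F)cc2)cc(-c2ccc3nc(NC4CC4)sc3n2)cc1C(N)=O` — 41700 nM
compound 3 `COc1c(NS(=O)(=O)c2ccc(F)cc2)cc(-c2ccc3nc(NC(=O)C4CC4)sc3n2)cc1C(N)=O` — 20500 nM
compound 2 `COc1c(NS(=O)(=O)C2CC2)cc(-c2ccc3nc(NC(C)=O)nn3c2)cc1C(N)=O` — "not determined" (no result reported)

Going by the values given here, in a functional assay on U-87MG ATCC cells (Homo sapiens) for antiproliferative activity, read by MTT assay, with a stated time of 72 h (on this read-out higher numbers stand for weaker inhibition and lower numbers for stronger inhibition), compound 3 gives the lowest of the two numbers; its nearest neighbour, compound 1, sits at 41700 nM, and the only single change measured, a 2.0-fold lower number from compound 1 to compound 3 (0.31 log units; beyond the scatter), is modest. Compound 4 `COc1c(NS(=O)(=O)c2ccc(F)cc2)cc(-c2ccc3nc(NC(C)=O)sc3n2)cc1C(N)=O` differs from compound 3 by methyl in place of cyclopropyl on a carbonyl carbon. No measured step touches this exact change, so the one step shown offers only a sense of scale, not a direction. On that basis compound 4 is expected to land near compound 3, with the step of a 1.1-fold higher number from compound 3 to compound 4 (0.03 log units; within the scatter) most likely inside the usual scatter. The estimate for compound 4 in this assay is 22000 nM, with a range from 8000 nM to 55000 nM.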

Compound 4, half-maximal inhibitory concentration: 21700 nM
Compound 4: the middle estimate sits 1.0-fold (0.01 log units) above what was measured; low and high end bracket the measured number.
By their numbers in this assay, from the lowest: compounds 3, 4 and 1 (each within the scatter of the next, the first and the last beyond it).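

In this assay methyl in place of cyclopropyl on a carbonyl carbon gives a 1.1-fold higher number from compound 3 to compound 4 (0.02 log units; within the scatter) and so, in this pair, the three-membered ring is not needed to keep the number where it stands. Acetyl in place of cyclopropyl on a nitrogen on an aromatic ring gives a 1.9-fold lower number from compound 1 to compound 4 (0.28 log units; within the scatter) and so putting a carbonyl on that nitrogen does not clearly separate compound 4 from compound 1. No measured evidence accounts for these results.

Open, going by these compounds, is how a longer acyl chain such as butanoyl, or a benzoyl group, would read on that nitrogen. On these data alone, a free amine there is also open.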